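This account rests on a few compounds, and the source may have more. Where it says the series, first, only, none or still open, it means among the compounds named here.

Measured so far:
- Compound 1, `O=C([C@@H]1CCCN(S(=O)(=O)c2ccc(S(=O)(=O)N3CC[C@@H](O)C3)cc2)C1)N1CCC(F)(F)CC1`: 330 nM
- Compound 2, `CCC(CC)S(=O)(=O)c1ccc(S(=O)(=O)N2CCC[C@@H](C(=O)N3CCC(F)(F)CC3)C2)cc1`: 40 nM
- Compound 3, `O=C([C@@H]1CCCN(S(=O)(=O)c2ccc(S(=O)(=O)C3CCC3)cc2)C1)N1CCC(F)(F)CC1`: 78 nM

These three share one core and differ only in the group attached to a sulfonyl sulfur. In a functional assay on BXPC-3 cells (Homo sapiens) for inhibition, read by MTT assay, with a stated time of 7 days (on this read-out higher numbers stand for weaker inhibition and lower numbers for stronger inhibition), compound 3 gives 78 nM, the second highest of the three numbers; its nearest neighbour is compound 2, and the gap a 2.0-fold higher number from compound 2 to compound 3 (0.29 log units; within the scatter) is small, while compound 1 is further away, with a 4.2-fold lower number from compound 1 to compound 3 (0.63 log units; beyond the scatter).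

Compound 4, `O=C([C@@H]1CCCN(S(=O)(=O)c2ccc(S(=O)(=O)C3COC3)cc2)C1)N1CCC(F)(F)CC1`, is the next step: oxetan-3-yl in place of cyclobutyl on a sulfonyl sulfur. Compared with compound 3 the group keeps its size and four-membered ring but gains one hydrogen-bond acceptor. Within the data shown here, no measured step covers exactly this exchange. Among the measured compounds shown here, the steps that come closest are a 4.2-fold lower number from compound 1 to compound 3 (0.63 log units; beyond the scatter) and an 8.3-fold lower number from compound 1 to compound 2 (0.92 log units; beyond the scatter), both showing that the only group bearing a donor and acceptor, in compound 1, gave the highest number; the step of a 2.0-fold higher number from compound 2 to compound 3 (0.29 log units; within the scatter) between two all-carbon groups stayed within the scatter. A move in this assay toward a somewhat higher number is therefore expected, though probably smaller than a 4.2-fold lower number from compound 1 to compound 3 (0.63 log units; beyond the scatter).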

Compound 4, half-maximal inhibitory concentration: 361 nM
For compound 4 the middle estimate is 2.4-fold (0.38 log units) below the measured one, and the stated range covers the measured number.
By their numbers in this assay, from the lowest: compounds 2 and 3 (each within the scatter of the next); then compounds 1 and 4 (each within the scatter of the next).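

In this assay, exchanging cyclobutyl for oxetan-3-yl on the sulfonyl sulfur shifts the result beyond the scatter (a 4.6-fold higher number from compound 3 to compound 4 (0.67 log units; beyond the scatter)), even though both groups have four heavy atoms and one four-membered ring. The gap to the open-chain pentan-3-yl group is similar in kind and somewhat wider (a 9.0-fold higher number from compound 2 to compound 4 (0.96 log units; beyond the scatter)), whereas the comparison with 3-hydroxypyrrolidin-1-yl stays within the scatter (a 1.1-fold higher number from compound 1 to compound 4 (0.04 log units; within the scatter)). Among these four compounds, the two groups with carbon only, in compounds 2 and 3, therefore give lower numbers than the two groups containing oxygen, in compounds 1 and 4, and no compound here goes against this.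

On these data alone, whether an amine, a carboxylic acid or a longer ether chain on the same sulfur would follow this pattern remains open. The data shown offer no explanation for these steps.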